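Ring-substituted cyclic peptides binding integrin alpha-5/beta-1

A few compounds are considered here, and "the series" means these few. Any claim that something is new, unique, unknown or untested is made for them only; others in the source may bear on it.

compound 1 `N=C(N)NCCC[C@@H]1NC(=O)CNC(=O)C[C@@H](C(=O)O)NC(=O)[C@@H](c2ccccc2)NC(=O)CNC1=O`: 19 nM
compound 2 `N=C(N)NCCC[C@@H]1NC(=O)CNC(=O)C[C@@H](C(=O)O)NC(=O)[C@@H](c2ccccc2)NC(=O)[C@H](Cc2ccc(O)cc2)NC1=O`: 39 nM

In an assay on a protein complex for binding affinity to integrin alpha-5/beta-1 (Homo sapiens), read by ELISA (a higher number here means a weaker inhibitor, a lower number a stronger inhibitor), compound 1 gives 19 nM and holds the lowest of the two numbers; the nearest is compound 2 with 39 nM. Compound 3 `N=C(N)NCCC[C@@H]1NC(=O)CNC(=O)C[C@@H](C(=O)O)NC(=O)[C@@H](c2ccccc2)NC(=O)[C@@H](Cc2c[nH]c3ccccc23)NC1=O` differs from compound 1 by (1H-indol-3-yl)methyl in place of hydrogen on a saturated ring carbon. For the measured compounds named here, the one measured step at the same ring carbon, a 2.1-fold higher number from compound 1 to compound 2 (0.31 log units; beyond the scatter), bears on this change and was modest. A step of similar size and the same direction is therefore expected here, a 1.8-fold higher number from compound 1 to compound 3 (0.27 log units; within the scatter). Compound 3 is estimated at 35 nM, with a range of 12 nM to 100 nM.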

Compound 3, half-maximal inhibitory concentration: 5.5 nM
Estimate against measurement, compound 3: 6.4-fold (0.80 log units) above, and the stated range ends above it.
By their numbers in this assay, from the lowest: compound 3; then compound 1; then compound 2.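

Placing (1H-indol-3-yl)methyl on this saturated ring carbon gives a 3.5-fold lower number from compound 1 to compound 3 (0.54 log units; beyond the scatter) in this assay, so substitution here can lower the number as well as raise it. Against a 2.1-fold higher number from compound 1 to compound 2 (0.31 log units; beyond the scatter) for 4-hydroxybenzyl, the direction of the step at this carbon depends on the group that enters. Nothing shown accounts for this difference between the two groups. Open, as far as these compounds go, is whether a plain benzyl, a methyl or a longer chain ending in an amine at this carbon would follow compound 3 or compound 2.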